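Rearranging the Acid Chain of Compound 2

A few compounds are considered here, and "the series" means these few. Any claim that something is new, unique, unknown or untested is made for them only; others in the source may bear on it.

Compound 1 `O=C(O)c1ccc(NCc2cccc(Oc3ccccc3)c2)cc1` and compound 2 `Cc1nc(-c2ccc(C(F)(F)F)cc2)sc1CNc1ccc(CCCC(=O)O)cc1` were both tested in a functional assay on CHO cells for agonist activity at Free fatty acid receptor 1 (Homo sapiens), read by a luciferase reporter; on this read-out higher numbers stand for larger maximal responses and lower numbers for smaller maximal responses. Compound 1 reaches 86%, whereas compound 2 reaches 44%, the lowest of the two numbers, and the gap between them lies beyond the usual scatter. Compound 3 `Cc1nc(-c2ccc(C(F)(F)F)cc2)sc1CNc1ccc(C(C)CC(=O)O)cc1` has the same atoms as compound 2, joined differently: 1-(carboxymethyl)ethyl in place of 3-carboxypropyl on an aromatic carbon. Among the compounds with values here, no measured pair shows what such a rearrangement does, so the expected step, a number 1 percentage points higher from compound 2 to compound 3 (within the scatter), is small and within the scatter. Compound 3 is estimated to reach 45% in this assay, between 25% and 70%.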

Compound 3, largest response reached (reported as percent of maximum), in percent of the reference or control that the assay uses: 109%
Compound 3: middle estimate off by 64 percentage points, on the low side, outside the stated range (above it).
By their numbers in this assay, from the lowest: compound 2; then compound 1; then compound 3.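

Replacing 3-carboxypropyl with 1-(carboxymethyl)ethyl on this aromatic carbon, para to a large group, keeps the same atoms, yet in this assay it gives a number 65 percentage points higher from compound 2 to compound 3 (beyond the scatter) with only their connection altered. Within the data shown here, at this position, then, how the acid chain is joined can strongly change the maximal response, which the earlier compounds could not show. Nothing available here explains the size of this step.

From the compounds shown here alone, whether a 1-(carboxymethyl)propyl chain or a tetrazole in place of the carboxylic acid would keep this larger response stays open. So does the effect of the branched chain on the core of compound 1.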